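The source may hold more compounds than are shown below. What is called first, only, known or untested is meant among the compounds shown, and "the series" means these compounds.

Working notes on the series in a functional assay on HCT-116 cells (Homo sapiens) for antiproliferative activity, read by MTT assay, with a stated time of 72 h; a higher number here means a weaker inhibitor, a lower number a stronger inhibitor.

Three compounds share one core and have a number. Compound 1 `CN(C(=O)c1ccccc1)c1ccc2[nH]c(-c3n[nH]c4ccccc34)cc2n1` gives 10600 nM in this assay. Compound 2 `CN(C(=O)CCc1ccccc1)c1ccc2[nH]c(-c3n[nH]c4ccccc34)cc2n1`, which carries a phenethyl in place of a phenyl on the carbonyl carbon, gives 11200 nM; the step of a 1.1-fold higher number from compound 1 to compound 2 (0.02 log units; within the scatter). Compound 3 `CN(C(=O)c1ccccc1)c1ccc2[nH]c(-c3n[nH]c4cc(Cl)ccc34)cc2n1`, with a chloro in place of hydrogen on an aromatic carbon, gives 13100 nM; the step of a 1.2-fold higher number from compound 1 to compound 3 (0.09 log units; within the scatter). All three numbers therefore lie within the scatter of each other, and compound 3 stands among them with no separation from compound 1 or compound 2.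

Compound 4 `CN(C(=O)c1ccccc1)c1ccc2[nH]c(-c3n[nH]c4cc(C#N)ccc34)cc2n1` has not yet been measured in this assay. It differs from compound 3 by cyano in place of chloro on an aromatic carbon. Among the measured compounds shown here, the only step that touches this position is the one from compound 1 to compound 3, the introduction of the chloro, which stayed within the scatter; the step from compound 1 to compound 2 concerns a different part of the molecule and does not bear on it. A step of the size seen there, none beyond the scatter, is therefore expected from compound 3 to compound 4, a 1.0-fold lower number from compound 3 to compound 4 (0.00 log units; within the scatter). Compound 4 is estimated to give 13000 nM in this assay, with a range from 6000 nM to 30000 nM.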

Compound 4, half-maximal inhibitory concentration: 24000 nM
Compound 4: the middle estimate sits 1.8-fold (0.27 log units) below what was measured; the range from low to high includes it.
By their numbers in this assay, from the lowest: compounds 1, 2, 3 and 4 (each within the scatter of the next, the first and the last beyond it).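

In this assay, replacing chloro with cyano on this aromatic carbon gives a 1.8-fold higher number from compound 3 to compound 4 (0.26 log units; within the scatter) and so does not separate the two groups. Among the compounds shown here, measured against the unsubstituted compound 1, however, cyano gives a 2.3-fold higher number from compound 1 to compound 4 (0.35 log units; beyond the scatter) and is the first single change to pass beyond the scatter, though only modestly, whereas the chloro step a 1.2-fold higher number from compound 1 to compound 3 (0.09 log units; within the scatter) does not. Substitution at this carbon can therefore raise the number measurably, but no evidence is available to account for this step.

The compounds shown leave open whether any group on this carbon can lower the number relative to compound 1, as only chloro and cyano are represented here, and an amine, a methoxy group or a carboxylic acid at the same place would test how far the trend extends. On these data alone, it also remains open whether cyano gives a step of similar size when the phenyl on the carbonyl carbon is replaced by the phenethyl of compound 2.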